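This account rests on a few compounds, and the source may have more. Where it says the series, first, only, none or still open, it means among the compounds named here.

In a functional assay on KYSE-450 cells (Homo sapiens) for inhibition, read by MTT assay, with a stated time of 48 h (on this read-out higher numbers stand for weaker inhibition and lower numbers for stronger inhibition), compound 1 `CCC(=O)N(Cc1ccc(OC)c(O)c1)c1cc(OC)c(OC)c(OC)c1` gives 98 nM, the lowest of the three numbers in hand. Compound 2 `C/C=C/C(=O)N(Cc1cc(OC)c(OC)c(OC)c1)c1ccc(OC)c(O)c1` gives 9160 nM and compound 3 `COc1ccc(CNc2cc(OC)c(OC)c(OC)c2)cc1F` gives 46200 nM; both gaps to compound 1 lie beyond the usual scatter, so compound 1 stands as the most potent of the measured set. Compound 4 `COc1ccc(CN(C(=O)CO)c2cc(OC)c(OC)c(OC)c2)cc1O` has not yet been measured. It differs from compound 1 in one place: hydroxy in place of methyl on a saturated chain carbon bound to a carbonyl carbon. Going by the values given here, no measured pair in the set covers this change, so nothing in the numbers fixes its size or direction. The step of a 3.1-fold higher number from compound 1 to compound 4 (0.49 log units; beyond the scatter) is expected to be modest, most likely toward a somewhat higher number, and may fall within the scatter. For compound 4 the estimate is 300 nM, within a range of 60 nM to 1500 nM.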

Compound 4, half-maximal inhibitory concentration: 370 nM
Compound 4: the middle estimate sits 1.2-fold (0.09 log units) below what was measured; measured number inside the range.
By their numbers in this assay, from the lowest: compound 1; then compound 4; then compound 2; then compound 3.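

In this assay, hydroxy in place of methyl on a saturated chain carbon bound to a carbonyl carbon gives a 3.8-fold higher number from compound 1 to compound 4 (0.58 log units; beyond the scatter), a modest step that lies beyond the scatter. Going by these compounds alone, this is the first direct reading at this position: the change adds one hydrogen-bond donor and one hydrogen-bond acceptor and costs only a modest loss of inhibition. No supporting data bear on what sets the size of this step.

From the compounds shown here alone, whether an amine, a carboxylic acid or a longer chain at this position would move the number further remains open. A single pair gives no trend.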